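Working notes: carboxy to methoxycarbonyl and solubility

This account rests on a few compounds, and the source may have more. Where it says the series, first, only, none or still open, it means among the compounds named here.

Measured so far in a physicochemical assay for solubility, read by spectrophotometry, with a stated time of 24 h, at pH 7.4; a lower number here means a less soluble compound, a higher number a more soluble compound:
Compound 1 `CN(/N=C/c1cccc(C(=O)O)c1)C(=O)c1ccc(N(C)C)cc1` gives > 67000 nM, a limit of the assay.
Compound 2 `COC(=O)c1cccc(/C=N/N(C)C(=O)c2ccc(N(C)C)cc2)c1` gives 8200 nM.
Compound 3 `CN(/N=C/c1ccc(C(=O)O)cc1)C(=O)c1ccc(N(C)C)cc1` gives > 67000 nM, again a limit.

Two of the three values thus sit at the limit of > 67000 nM in this assay, at which 2 of the 3 values shown sit, and only compound 2 returns a number. Among the measured compounds shown here, the one measured step is an at least 8.1-fold lower number from compound 1 to compound 2 (0.91 log units; beyond the scatter), made by methyl in place of hydrogen on an oxygen next to a carbonyl group. Compound 1 and compound 3 share the same atoms joined differently; the difference between the two cores is not broken down here.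

Compound 4 `COC(=O)c1ccc(/C=N/N(C)C(=O)c2ccc(N(C)C)cc2)cc1` is yet to be measured in this assay. It differs from compound 3 by methyl in place of hydrogen on an oxygen next to a carbonyl group, the same change as from compound 1 to compound 2, at a place described in the same words. The expected step is an at least 8.3-fold lower number from compound 3 to compound 4 (0.92 log units; beyond the scatter), resting on the measured at least 8.1-fold lower number from compound 1 to compound 2 (0.91 log units; beyond the scatter). For compound 4 the estimated value is 8000 nM, with an expected range from 2500 nM to 30000 nM.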

Compound 4, solubility: 1400 nM
For compound 4 the middle estimate is 5.7-fold (0.76 log units) above the measured one, outside the stated range (below it).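

In this assay, carboxy to methoxycarbonyl goes the same way on both cores, with an at least 47-fold lower number from compound 3 to compound 4 (1.67 log units; beyond the scatter) and an at least 8.1-fold lower number from compound 1 to compound 2 (0.91 log units; beyond the scatter). The direction of the change therefore carries from the core of compound 1 to the core of compound 3, but this rests on only these two matched pairs and says nothing about any further core. Neither the true size of either step nor any real difference in size between the two cores can be read, because both steps start from a limit rather than a number: the limit of > 67000 nM in this assay, at which 2 of the 4 values shown sit.

The compounds shown leave open whether a longer chain on the same oxygen, such as ethyl, would follow methyl in the same direction. They also leave open how the series would read with a nitrile or a primary amide standing where the carboxy group stands on either core.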